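The source may hold more compounds than are shown below. What is called first, only, known or untested is meant among the compounds shown, and "the series" means these compounds.

Measured compounds:
compound 1 `CO[C@@H]1CC=C2NN(c3cc4ccccc4[nH]3)C(=O)C[C@]2(c2ccccc2)O1` — > 38000 nM
compound 2 `COc1cc(OC)cc(N2NC3=CC[C@@H](OC)O[C@@]3(c3ccncc3)CC2=O)c1` — > 51000 nM

In an ADME assay on MCF-10A cells (Homo sapiens) for inhibition, read by sulforhodamine B assay, with a stated time of 48 h (on this read-out higher numbers stand for weaker inhibition and lower numbers for stronger inhibition), compound 1 gives > 38000 nM, which is a limit of the assay and not a number. Compound 1 therefore stands at the limit of > 38000 nM in this assay, at which 1 of the 2 values shown sits. Compound 2 likewise gives only > 51000 nM, again a limit and not a number, so it stands at the limit of > 51000 nM in this assay, at which 1 of the 2 values shown sits. Going by the values given here, both measured values are limits; no step between measured compounds can be sized, and the series so far shows no inhibition within the tested range.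

Compound 3 `CO[C@@H]1CC=C2NN(c3cc4ccccc4[nH]3)C(=O)C[C@]2(c2ccncc2)O1` is not yet measured. It differs from compound 1 by pyridin-4-yl in place of phenyl on a saturated ring carbon. Among the compounds with values here, with no measured step to lean on, the step that the limit leaves unreadable from compound 1 to compound 3 is expected to be none beyond the scatter, with the read-out most likely remaining a limit. Compound 3 is expected to give 50000 nM, in a range from 20000 nM to 200000 nM.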

Compound 3, half-maximal inhibitory concentration: > 55000 nM
Compound 3: only a limit was reported (the forecaster's own chance of this, stated with the estimate: 85%); at least 1.1-fold (0.04 log units) between middle value and limit.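

Compound 1 and compound 3 both give only limits of the assay in this assay, so the step for pyridin-4-yl in place of phenyl on a saturated ring carbon cannot be read. The compounds shown leave open whether this change alters inhibition, and at what concentration any of them inhibits.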